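Pyridin-3-yl in place of pyridin-4-yl

This account rests on a few compounds, and the source may have more. Where it says the series, first, only, none or still open, it means among the compounds named here.

Compound 1 `N#Cc1ccc(N2CCc3cc(-c4cnc5ccccc5c4)ccc3C2)cc1C(F)(F)F`: > 30000 nM (a limit of the assay)
Compound 2 `N#Cc1ccc(N2CCc3cc(-c4ccncc4)ccc3C2)cc1C(F)(F)F`: 3500 nM

Among the compounds with values here, in a functional assay on VCaP cells (Homo sapiens) for antiproliferative activity, read by CCK-8 assay, with a stated time of 6 days (a lower number here means a stronger inhibitor, a higher number a weaker inhibitor), compound 2 gives 3500 nM, the only actual number so far. Compound 1 gives > 30000 nM, which is a limit of the assay.

Next comes compound 3 `N#Cc1ccc(N2CCc3cc(-c4cccnc4)ccc3C2)cc1C(F)(F)F`. The change is pyridin-3-yl in place of pyridin-4-yl on an aromatic carbon. The two compounds have the same atoms, joined differently.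

Within the data shown here, only one measured step bears on this: an at least 8.5-fold lower number from compound 1 to compound 2 (0.93 log units; beyond the scatter). It replaced quinolin-3-yl with pyridin-4-yl, a larger swap than the present one, so a much smaller step is expected here. Since pyridin-3-yl shares its numbering with quinolin-3-yl, the expected direction is towards a higher number, with a size close to the usual scatter. The estimated step is a 1.7-fold higher number from compound 2 to compound 3 (0.23 log units; within the scatter). For compound 3 the expected value is 6000 nM, with an estimated range of 1800 nM to 20000 nM.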

Compound 3, half-maximal inhibitory concentration: 2530 nM
Compound 3: middle estimate off by 2.4-fold (0.38 log units), on the high side, within the range that was stated.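

In this assay, pyridin-3-yl in place of pyridin-4-yl gives a 1.4-fold lower number from compound 2 to compound 3 (0.14 log units; within the scatter), so compound 2 and compound 3 cannot be told apart, and the place of the ring nitrogen makes no measurable difference here. Pyridin-3-yl in place of quinolin-3-yl gives an at least 11-fold lower number from compound 1 to compound 3 (1.07 log units; beyond the scatter), so both pyridines shown stand well clear of compound 1, and sharing the 3-yl attachment with quinolin-3-yl does not keep the number high. That step is only a minimum because compound 1 stands at a limit of the assay: the limit of > 30000 nM in this assay, at which 1 of the 3 values shown sits.

Going by these compounds, what stays open is whether the ring nitrogen is needed at all, which a plain phenyl group on this aromatic carbon would address. Also open, on these data alone, is how a small group on the pyridine, such as an amine or a methoxy group, would shift the number.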